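The compounds below may be only part of what the source reports. "The series", "measured", "known", "first", "only" and "open" are said of these compounds alone.

Compound 1 `CC[C@@H](Nc1c(C#N)c(-c2ccc(-c3ccccc3OC)cc2)nc2cnccc12)C(N)=O` is one of two compounds with a value in a physicochemical assay for lipophilicity, read by HPLC, at pH 7.5; on this read-out higher numbers stand for higher lipophilicity and lower numbers for lower lipophilicity. In this assay compound 1 gives 2.7, the lower of the two numbers. Compound 2 `CCOc1ccccc1-c1ccc(-c2nc3cnccc3c(N[C@H](CC(C)C)C(N)=O)c2C#N)cc1` gives 3.4 in this assay, a number that lies beyond the scatter above compound 1; the two compounds differ in more than one place, so the gap between them is not traced to any single change.

Compound 3 `CC[C@@H](Nc1c(C#N)c(-c2ccc(-c3ccc(Cl)cc3)cc2)nc2cnccc12)C(N)=O` has not been measured in this assay. It differs from compound 1 in one place: 4-chlorophenyl in place of 2-methoxyphenyl on an aromatic carbon. Going by the values given here, no measured pair shows this exact change, so the size of the step rests on expectation alone. The step is expected to go upward and beyond the scatter, by about a number 0.70 log units higher from compound 1 to compound 3 (beyond the scatter). Compound 3 is therefore estimated to give 3.4 in this assay, with a likely range from 3 to 3.9.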

Compound 3, distribution coefficient: 3.1
Beside the measured number, compound 3's estimate is 0.30 log units above it, within the range that was stated.
By their numbers in this assay, from the lowest: compound 1; then compounds 3 and 2 (each within the scatter of the next).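

In this assay, putting 4-chlorophenyl in place of 2-methoxyphenyl on this aromatic carbon gives a number 0.40 log units higher from compound 1 to compound 3 (beyond the scatter). Going by these compounds alone, this is the only measured pair here that differs in one place, so unlike the gap between the earlier two compounds, this step belongs to a single change at a single position. That change replaces both the atom attached to the ring and its place on the ring, and nothing measured here divides the step between those two parts or explains it.

The compounds shown leave open how 4-methoxyphenyl or 2-chlorophenyl would read, and either would separate the effect of the group from that of its place. They also leave open how this position would respond to a ring carrying an amine or a carboxylic acid.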